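The source may report more compounds than this note shows. Statements on the series, on what has been measured and on what is new or still open speak of the compounds shown alone.

Measured compounds:
Compound 1 `Cc1cc(C)cc(-c2cc(C)c(Nc3ccnc(Nc4ccc(C#N)cc4)n3)c(C)c2)c1` gives 4140 nM in an ADME assay on MT4 cells (Homo sapiens) for cytotoxicity, read by MTT assay, with a stated time of 4 days; on this read-out lower numbers stand for higher toxicity in this test and higher numbers for lower toxicity in this test.
Compound 2 `Cc1cccc(-c2cc(C)c(Nc3ccnc(Nc4ccc(C#N)cc4)n3)c(C)c2)c1` gives 3670 nM in this assay.
Compound 3 `Cc1cc(-c2ccccc2F)cc(C)c1Nc1ccnc(Nc2ccc(C#N)cc2)n1` gives 2120 nM in this assay.

All three compounds share one core and differ only in the aromatic group carried on it. Compound 3 has the lowest of the three numbers, yet its distance to the others is small: a 2.0-fold lower number from compound 1 to compound 3 (0.29 log units; within the scatter) and a 1.7-fold lower number from compound 2 to compound 3 (0.24 log units; within the scatter), both within the scatter, so the three numbers cannot be told apart with confidence. Within the data shown here, the one change among the methyl-bearing groups, a 1.1-fold lower number from compound 1 to compound 2 (0.05 log units; within the scatter), is likewise within the scatter.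

Compound 4 `COc1ccc(-c2cc(C)c(Nc3ccnc(Nc4ccc(C#N)cc4)n3)c(C)c2)cc1` is not yet measured. Its difference from compound 3 is 4-methoxyphenyl in place of 2-fluorophenyl on an aromatic carbon. Among the measured compounds shown here, the steps that bear on this change are the exchanges of one aromatic group for another on this position, and every one of them stayed within the scatter. The expected step in this assay is therefore small, a 1.4-fold higher number from compound 3 to compound 4 (0.15 log units; within the scatter), leaning toward the numbers of compound 1 and compound 2. Compound 4 is estimated to give 3000 nM, with a range from 1500 nM to 6500 nM.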

Compound 4, half-maximal cytotoxic concentration: 2890 nM
Compound 4: middle estimate off by 1.0-fold (0.02 log units), on the high side; measured number inside the range.
By their numbers in this assay, from the lowest: compounds 3, 4, 2 and 1 (each within the scatter of the next).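

Among these compounds, compound 4 puts an oxygen-bearing group on this position for the first time: its 4-methoxyphenyl has one hydrogen-bond acceptor, where the 2-fluorophenyl has none. In this assay this exchange stays within the scatter against all three earlier compounds, with a 1.4-fold higher number from compound 3 to compound 4 (0.13 log units; within the scatter), a 1.3-fold lower number from compound 2 to compound 4 (0.10 log units; within the scatter) and a 1.4-fold lower number from compound 1 to compound 4 (0.16 log units; within the scatter). The four aromatic groups shown on this position therefore cannot be told apart in this test, and adding the oxygen made no readable difference.

No measurement shown here gives a reason why the numbers lie so close together. On these data alone, it remains open whether a group of another kind on this position, such as an amine or a carboxylic acid, would shift the number beyond the scatter.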